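Swapping 2-methoxyphenyl for pyridin-2-yl

The source may hold more compounds than are shown below. What is called first, only, known or untested is meant among the compounds shown, and "the series" means these compounds.

Compound 1 (`S=c1oc(-c2ccc3c(c2)OCCO3)nn1CN1CCN(C(c2ccccc2)c2ccccc2)CC1`) reads > 50000 nM in a functional assay on BGC-823 cells (Homo sapiens) for antiproliferative activity, read by MTT assay, with a stated time of 48 h (a higher number here means a weaker inhibitor, a lower number a stronger inhibitor), and that is a limit of the assay, not a number. Compound 2 (`S=c1oc(-c2ccc3c(c2)OCCO3)nn1CN1CCN(c2cccc(Cl)c2)CC1`) reads > 50000 nM in this assay and that too is only a limit. Among the compounds with values here, compound 3 (`COc1ccccc1N1CCN(Cn2nc(-c3ccc4c(c3)OCCO4)oc2=S)CC1`) gives 19500 nM as the only true number so far. Compound 4 (`S=c1oc(-c2ccc3c(c2)OCCO3)nn1CN1CCN(c2ccccn2)CC1`) carries pyridin-2-yl in place of 2-methoxyphenyl on an amine nitrogen in a ring. Within the data shown here, the one measured swap at this place is an at least 2.5-fold lower number from compound 2 to compound 3 (0.40 log units; beyond the scatter) and it is at least modest, beyond the scatter. Among the measured compounds shown here, that size is the only guide, so a similar move toward weaker inhibition is expected, a 1.6-fold higher number from compound 3 to compound 4 (0.22 log units; within the scatter) in this assay and a reading at the limit is possible. For compound 4 the estimate is 32000 nM with an expected range from 13000 nM to 50000 nM in the same test.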

Compound 4, half-maximal inhibitory concentration: 25900 nM
Estimate against measurement, compound 4: 1.2-fold (0.09 log units) above; the range from low to high includes it.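

The change to pyridin-2-yl gives a 1.3-fold higher number from compound 3 to compound 4 (0.12 log units; within the scatter), so in this assay this ring nitrogen carries a six-membered aromatic ring with a hetero atom with no readable change from 2-methoxyphenyl. Against 3-chlorophenyl, the same group gives an at least 1.9-fold lower number from compound 2 to compound 4 (0.28 log units; that floor lies within the scatter), so this step does not clearly separate the two groups. It can be read only as a floor because compound 2 gives a limit, not a number: the limit of > 50000 nM in this assay, at which 2 of the 4 values shown sit.

As far as these compounds go, whether a longer chain or a carboxylic acid at this place would give a clearly lower number remains open.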